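Swapping the pyrazole for a substituted phenyl ring

A few compounds are considered here, and "the series" means these few. Any claim that something is new, unique, unknown or untested is made for them only; others in the source may bear on it.

Measured compounds:
Compound 1, `O=C(NCCCNc1nc(Nc2cccnc2)ncc1C1CC1)C1CCC1`, gives 13 nM in an assay on isolated protein for inhibition of serine/threonine-protein kinase TBK1 (Homo sapiens); a higher number here means a weaker inhibitor, a lower number a stronger inhibitor.
Compound 2, `O=C(NCCCNc1nc(Nc2cnn(C3CC3)c2)ncc1C1CC1)C1CCC1`, gives 10 nM in this assay.
Compound 3, `O=C(NCCCNc1nc(Nc2cnn(C3CCOCC3)c2)ncc1C1CC1)C1CCC1`, gives 2 nM in this assay.

Compound 2 stands second highest of the three numbers in this assay: the values of compound 1 and compound 2 lie within the scatter of each other (a 1.3-fold lower number from compound 1 to compound 2 (0.11 log units; within the scatter)), while compound 3 sits clearly lower (a 5.0-fold lower number from compound 2 to compound 3 (0.70 log units; beyond the scatter)).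

Compound 4, `CN(C)Cc1ccc(Nc2ncc(C3CC3)c(NCCCNC(=O)C3CCC3)n2)cc1`, is not yet measured. It differs from compound 2 in that (4-((dimethylamino)methyl)phenyl in place of 1-cyclopropyl-1H-pyrazol-4-yl on a nitrogen on an aromatic ring). The step from compound 1 to compound 2, which exchanges a six-membered aromatic ring for the 1-cyclopropyl-1H-pyrazol-4-yl group at the same position, stayed within the scatter, so a return to a six-membered aromatic ring carrying a different group is the nearest comparison. The step from compound 2 to compound 3 changed only the group on the pyrazole nitrogen and does not bear directly on a phenyl ring. Among the measured compounds shown here, no measured step tells how 4-((dimethylamino)methyl)phenyl behaves here.

Compound 4 is therefore expected to give about 9 nM in this assay, between 3 nM and 30 nM. The expected step of a 1.1-fold lower number from compound 2 to compound 4 (0.05 log units; within the scatter) would lie within the scatter.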

Compound 4, half-maximal inhibitory concentration: 6 nM
Beside the measured number, compound 4's estimate is 1.5-fold (0.18 log units) above it, and the stated range covers the measured number.
By their numbers in this assay, from the lowest: compound 3; then compounds 4, 2 and 1 (each within the scatter of the next, the first and the last beyond it).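

At this place, on a nitrogen on an aromatic ring, the shared core accepts a much changed group in this assay: a six-membered aromatic ring of carbon only, bearing a dimethylamino group on a methyl link, replaces the 1-cyclopropyl-1H-pyrazol-4-yl group and the result stays within the scatter (a 1.7-fold lower number from compound 2 to compound 4 (0.22 log units; within the scatter)). Set against the other six-membered ring, pyridin-3-yl, the same group gives a modest step beyond the scatter (a 2.2-fold lower number from compound 1 to compound 4 (0.34 log units; beyond the scatter)), so the earlier finding that this position accepts both pyridin-3-yl and a substituted pyrazole now extends to a phenyl ring with a substituent carrying an amine. Nothing given here accounts for either step.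

As far as these compounds go, what remains open is how much of the step from compound 1 belongs to the phenyl ring and how much to the dimethylamino group, which a bare phenyl ring would help to separate. Also open, from the compounds shown here alone, is how the number would respond if a morpholine or a piperidine took the place of the dimethylamino group, or if the methyl link gave way to a longer chain.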